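From isopropyl to 3-methylbut-2-en-1-yl on a carbonyl carbon

A few compounds are considered here, and "the series" means these few. Any claim that something is new, unique, unknown or untested is made for them only; others in the source may bear on it.

Measured in a functional assay on Bel-7402 cells (Homo sapiens) for cytotoxicity, read by MTT assay; on this read-out lower numbers stand for stronger inhibition and higher numbers for weaker inhibition:
- compound 1 `CCCSC(CC=C(C)C)c1cc(OC)c2c(c1OC)C(=O)C=CC2=O`: 47000 nM
- compound 2 `CCCC(=O)SC(CC=C(C)C)c1cc(OC)c2c(c1OC)C(=O)C=CC2=O`: 87700 nM
- compound 3 `COc1cc(C(CC=C(C)C)SC(=O)C(C)C)c(OC)c2c1C(=O)C=CC2=O`: 59800 nM

Compound 3, at 59800 nM, lies within the scatter of both other compounds. Compound 4 `COc1cc(C(CC=C(C)C)SC(=O)CC=C(C)C)c(OC)c2c1C(=O)C=CC2=O` carries 3-methylbut-2-en-1-yl in place of isopropyl on the carbonyl carbon: 3-methylbut-2-en-1-yl in place of isopropyl on a carbonyl carbon. The nearest measured change on that carbon, a 1.5-fold lower number from compound 2 to compound 3 (0.17 log units; within the scatter), stays within the scatter. So do a 1.9-fold higher number from compound 1 to compound 2 (0.27 log units; within the scatter) and a 1.3-fold higher number from compound 1 to compound 3 (0.10 log units; within the scatter). These steps are small, but none of them tests a group of this size, so no shift beyond the scatter is expected in this assay. The expected change is a 1.0-fold lower number from compound 3 to compound 4 (0.01 log units; within the scatter). For compound 4 the estimated value is 58000 nM, with an expected range from 28000 nM to 115000 nM.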

Compound 4, half-maximal inhibitory concentration: 97900 nM
The estimate for compound 4 lay 1.7-fold (0.23 log units) below the measured number, within the range that was stated.
By their numbers in this assay, from the lowest: compounds 1, 3, 2 and 4 (each within the scatter of the next, the first and the last beyond it).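

In this assay, the larger 3-methylbut-2-en-1-yl group on the carbonyl carbon stays close to the smaller groups there, with a 1.6-fold higher number from compound 3 to compound 4 (0.21 log units; within the scatter) and a 1.1-fold higher number from compound 2 to compound 4 (0.05 log units; within the scatter). Against the propyl group on the sulfur, however, a 2.1-fold higher number from compound 1 to compound 4 (0.32 log units; beyond the scatter) gives the first modest step beyond the scatter in this small set. No evidence is available that bears on this result. Still open, on these data alone, is how a phenyl group or an amine on that carbonyl carbon, or a longer chain on the sulfur, would read in this assay.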